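This account rests on a few compounds, and the source may have more. Where it says the series, first, only, none or still open, it means among the compounds named here.

Within the data shown here, compound 2 `COc1ccc(-c2cc3nccc(-c4cc(OC)c(OC)c(OC)c4)n3n2)cc1F` is the one member of this set with a numerical result in a functional assay on MCF7 cells (Homo sapiens) for inhibition, read by CCK-8 assay, with a stated time of 48 h (on this read-out lower numbers stand for stronger inhibition and higher numbers for weaker inhibition), where compound 2 gives 183 nM. Compound 1 `COc1ccc(-c2cc3nccc(-c4cc(OC)c(OC)c(OC)c4)n3n2)cc1[N+](=O)[O-]` reaches only a limit in this assay, giving > 10000 nM. Compound 3 `CCOC(=O)c1ccc(-c2cc3nccc(-c4cc(OC)c(OC)c(OC)c4)n3n2)cc1` likewise reaches only a limit in this assay, giving > 10000 nM. Among the measured compounds shown here, the single step measured between neighbours, an at least 54-fold lower number from compound 1 to compound 2 (1.73 log units; beyond the scatter), is large, and two of the three results sit at the limit of > 10000 nM in this assay, at which 2 of the 3 values shown sit, so the group on this aromatic carbon of the shared core has a strong hold on the read-out. Compound 4 `COc1cc(-c2ccnc3cc(-c4cn(C)c5ccccc45)nn23)cc(OC)c1OC` is unmeasured and differs from compound 2 by 1-methyl-1H-indol-3-yl in place of 3-fluoro-4-methoxyphenyl on an aromatic carbon. For the measured compounds named here, no measured step covers this exchange, which swaps the whole group rather than one substituent on it, so its direction is open; an at least 54-fold lower number from compound 1 to compound 2 (1.73 log units; beyond the scatter) only warns that a change at this carbon can be large. For compound 4 an estimate of 450 nM is given, with a range from 60 nM to 5000 nM. The step this estimate means for compound 4, a 2.5-fold higher number from compound 2 to compound 4 (0.39 log units; beyond the scatter), is expected to be a modest loss with wide uncertainty.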

Compound 4, half-maximal inhibitory concentration: 95 nM
Compound 4: middle estimate off by 4.7-fold (0.68 log units), on the high side, and the stated range covers the measured number.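

In this assay, putting 1-methyl-1H-indol-3-yl in place of 3-fluoro-4-methoxyphenyl gives a 1.9-fold lower number from compound 2 to compound 4 (0.28 log units; within the scatter), so the two results cannot be told apart. This aromatic carbon therefore holds either of two quite different groups, a single six-membered aromatic ring or a five-membered aromatic ring together with a six-membered one, with no measurable change in the read-out. Among these compounds, the earlier step, an at least 54-fold lower number from compound 1 to compound 2 (1.73 log units; beyond the scatter), showed only that one substituent exchange here can matter greatly, whereas this exchange of the whole group leaves the result in place.

From the compounds shown here alone, it remains open whether the methyl on the 1-methyl-1H-indol-3-yl group could give way to a longer chain, or whether an amine or a carboxylic acid on that group would keep the result. The size of the largest losses also stays unknown, as those results are limits and not numbers: the limit of > 10000 nM in this assay, at which 2 of the 4 values shown sit.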